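Compound 2 to compound 3: estimating from a limit

This account rests on a few compounds, and the source may have more. Where it says the series, first, only, none or still open, it means among the compounds named here.

Compound 1 (`O=[N+]([O-])c1c(CS(=O)(=O)c2ccccc2)nc2c(C#Cc3ccccc3)cc(Cl)cn12`) gives > 3900 nM in an ADME assay on HepG2 cells (Homo sapiens) for cytotoxicity, read by MTT assay, with a stated time of 72 h (on this read-out higher numbers stand for lower toxicity in this test and lower numbers for higher toxicity in this test), which is a limit of the assay and not a number. Compound 2 (`O=[N+]([O-])c1c(CS(=O)(=O)c2ccccc2)nc2c(C#Cc3cccc(F)c3)cc(Cl)cn12`) gives > 3900 nM in this assay, which is again a limit. Compound 2 therefore has no readable value, and the series offers no number to start from: the limit of > 3900 nM in this assay, at which 2 of the 2 values shown sit.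

Compound 3 (`Nc1ccc(C#Cc2cc(Cl)cn3c([N+](=O)[O-])c(CS(=O)(=O)c4ccccc4)nc23)cc1`) has 4-aminophenyl in place of 3-fluorophenyl on a triple-bonded carbon. Going by the values given here, no measured step covers this exchange. The nearest is a step that the two limits leave unreadable from compound 1 to compound 2, for fluoro in place of hydrogen on an aromatic carbon, and it gives no size to carry over. Among the compounds with values here, the only guide is that both measured compounds stand at the same limit, so compound 3 is expected to stay near it, with no step in either direction beyond the scatter. The estimated change is a step that the limit leaves unreadable from compound 2 to compound 3, and the assay may again report only a limit. For compound 3 the expected half-maximal cytotoxic concentration is 5500 nM, within an estimated range of 2000 nM to 16000 nM.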

Compound 3, half-maximal cytotoxic concentration: > 3900 nM
Compound 3: a limit, no number (the forecaster's own chance of this, stated with the estimate: 65%); the middle value does not contradict the limit.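

No step can be read between compound 1, compound 2 and compound 3 in this assay, since each gives a limit and not a number: the limit of > 3900 nM in this assay, at which 3 of the 3 values shown sit.

The compounds shown leave open where the actual half-maximal cytotoxic concentration of each lies, and so whether the fluoro or the amino exchange changes it at all.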